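Compound 4: a Cyano Group Added to Compound 2

The source may report more compounds than this note shows. Statements on the series, on what has been measured and on what is new or still open speak of the compounds shown alone.

Of the compounds shown here, three have so far been measured in an in vitro functional assay on HEK285-7 cells for antagonist activity at prostaglandin D2 receptor 2 (Homo sapiens), read by BRET and beta-arrestin recruitment; a higher number here means a weaker inhibitor, a lower number a stronger inhibitor. Compound 1 `Cc1nc(-c2ccc(Cl)cc2)c(CC(=O)O)s1` gives 41000 nM, compound 3 `O=C(O)Cc1sc(C(c2ccccc2)c2ccccn2)nc1-c1ccc(Cl)cc1` gives 1900 nM, and compound 2 `O=C(O)Cc1sc(C(c2ccc(F)cc2)c2ccc(F)cc2)nc1-c1ccccc1` gives 240 nM. Compound 2 therefore stands lowest of the three; its nearest neighbour is compound 3 and its furthest is compound 1, and both gaps lie beyond the usual scatter, so compound 2 is the strongest inhibitor of this small set.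

Compound 4 `N#Cc1ccc(-c2nc(C(c3ccc(F)cc3)c3ccc(F)cc3)sc2CC(=O)O)cc1` differs from compound 2 in one place: cyano in place of hydrogen on an aromatic carbon. Going by the values given here, no measured pair in the set shares this change, so its size has no direct precedent here. The account expects the step of a 1.2-fold lower number from compound 2 to compound 4 (0.08 log units; within the scatter) in this assay to be small, likely within the scatter and, if anything, toward a slightly lower number. For compound 4 the estimate in this assay is 200 nM, with a range from 70 nM to 600 nM.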

Compound 4, half-maximal inhibitory concentration: 1500 nM
Estimate against measurement, compound 4: 7.5-fold (0.88 log units) below; measured number above the stated range.
By their numbers in this assay, from the lowest: compound 2; then compounds 4 and 3 (each within the scatter of the next); then compound 1.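

Going by these compounds alone, the change from phenyl to 4-cyanophenyl gives a 6.3-fold higher number from compound 2 to compound 4 (0.80 log units; beyond the scatter) in this assay and is the first step in this set that can be read between two compounds differing in one place. It shows that this position, on a six-membered aromatic ring of carbon only and para to a large group, is not indifferent to substitution: with the rest of compound 2 kept, cyano in place of hydrogen weakens inhibition by more than the scatter. Nothing measured here accounts for that loss.

Still open, from the compounds shown here alone, is whether the loss belongs to cyano alone or would also follow from a methoxy group or an amine on the same carbon. A single step also leaves open whether cyano would have a similar effect on a different core.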